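Resolving the stereocentre of compound 2

The compounds below may be only part of what the source reports. "The series", "measured", "known", "first", "only" and "open" are said of these compounds alone.

Within the data shown here, compound 2 `CC(Sc1nc2c(cnn2C)c(=O)n1-c1ccccc1)c1ccccc1` stands highest of the two numbers measured so far: in an assay on PEO1 cells for inhibition of Retinaldehyde dehydrogenase 3 (Homo sapiens), read by flow cytometry, with a stated time of 30 min, tested at 1 uM (on this read-out higher numbers stand for more inhibition at the one concentration tested (going by the name of the read-out) and lower numbers for less inhibition), compound 2 gives 47%. Among the measured compounds shown here, its only neighbour, compound 1 `CC(Sc1nc2c(cnn2C)c(=O)n1-c1ccccc1)c1cncnc1`, gives 39% in this assay, and the step of a number 8 percentage points higher from compound 1 to compound 2 (within the scatter) came with phenyl in place of pyrimidin-5-yl on a saturated chain carbon bound to a saturated chain carbon and a sulfur. Compound 3 `C[C@H](Sc1nc2c(cnn2C)c(=O)n1-c1ccccc1)c1ccccc1` differs from compound 2 in configuration alone: the two compounds have the same atoms and bonds; at least one stereo element is drawn with a configuration in one of them and without one in the other: 1 of 1 stereo elements differ; a stereocentre at a saturated chain carbon is drawn without a configuration in compound 2 and S in compound 3. For the measured compounds named here, no measured step compares two configurations of one stereocentre, so the single ring-swap step gives no direct guidance here. Compound 3 may carry more or less of the inhibition of compound 2, and the numbers cannot say which. Compound 3 is therefore expected near compound 2, at an estimated 50% with a wide range from 25% to 75%, the expected step of a number 3 percentage points higher from compound 2 to compound 3 (within the scatter) lying within the scatter at its middle but possibly beyond it in either direction.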

Compound 3, a percentage reported as inhibition, at one concentration (the size of the read-out at that concentration, not a potency): 2%
For compound 3 the middle estimate is 48 percentage points above the measured one, and the stated range ends above it.
By their numbers in this assay, from the lowest: compound 3; then compounds 1 and 2 (each within the scatter of the next).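

The stereocentre at the saturated chain carbon is a sensitive position: in this assay, drawing it as S comes with a number 45 percentage points lower from compound 2 to compound 3 (beyond the scatter), whereas the ring swap stayed within the scatter. The loss also shows against the pyrimidin-5-yl compound, with a number 37 percentage points lower from compound 1 to compound 3 (beyond the scatter), although that step carries both the ring change and the drawn configuration. With no atom or bond changed, the large step from the undefined to the S drawing can be placed at this stereocentre alone: the fact that one of compounds 2 and 3 is drawn with a defined configuration and the other without, at the place where they differ.

Going by these compounds, the configurational make-up of compound 2 stays open, as does whether the R configuration keeps or exceeds its inhibition. Also open, on these data alone, is how an ethyl group in place of the methyl on this carbon, or an amine on the phenyl ring, would read once the configuration is defined.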